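The source may report more compounds than this note shows. Statements on the series, on what has been measured and on what is new or still open speak of the compounds shown alone.

Of the compounds shown here, three have been measured in an ADME assay on HT-29 cells (Homo sapiens) for cytotoxicity, read by MTT assay, with a stated time of 72 h; on this read-out lower numbers stand for stronger inhibition and higher numbers for weaker inhibition.
Compound 1 `COc1ccc(C2=C(c3cc(OC)c(OC)c(OC)c3)C(=O)CC2O[SiH2]C(C)(C)C)cc1` gives > 100 ug/mL, which is a limit of the assay and not a number.
Compound 2 `COc1ccc(OC)c(C2=C(c3cc(OC)c(OC)c(OC)c3)C(=O)CC2O[SiH2]C(C)(C)C)c1` gives 5 ug/mL.
Compound 3 `COc1cc(C2=C(c3ccccc3)C(O[SiH2]C(C)(C)C)CC2=O)cc(OC)c1OC` gives > 100 ug/mL, again a limit of the assay and not a number.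

Compound 3 therefore stands at the limit of > 100 ug/mL in this assay, at which 2 of the 3 values shown sit, and compound 1 sits there as well, so the two cannot be ranked against each other; only compound 2 gives a number. Compound 4 `COCOc1cc(C2=C(c3cc(OC)c(OC)c(OC)c3)C(=O)CC2O[SiH2]C(C)(C)C)ccc1OC` has not been measured; it differs from compound 3 by 4-methoxy-3-(methoxymethoxy)phenyl in place of phenyl on a double-bonded ring carbon. The step that bears most directly on this change is an at least 20-fold higher number from compound 2 to compound 3 (1.30 log units; beyond the scatter), and an at least 20-fold lower number from compound 1 to compound 2 (1.30 log units; beyond the scatter) points the same way, whereas a step that the two limits leave unreadable from compound 1 to compound 3. The group entering compound 4 is not the 2,5-dimethoxyphenyl of compound 2, so a smaller gain is expected, an at least 3.3-fold lower number from compound 3 to compound 4 (0.52 log units; beyond the scatter). Compound 4 is estimated at 30 ug/mL, within a range from 3 ug/mL to 100 ug/mL.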

Compound 4, half-maximal inhibitory concentration: 43 ug/mL
For compound 4 the middle estimate is 1.4-fold (0.16 log units) below the measured one; the measured number falls inside the stated range.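

In this assay, this position tolerates more than the 2,5-dimethoxyphenyl of compound 2 if a measurable number is the test: 4-methoxy-3-(methoxymethoxy)phenyl in place of phenyl gives an at least 2.3-fold lower number from compound 3 to compound 4 (0.36 log units; beyond the scatter), and methoxymethoxy in place of hydrogen on an aromatic carbon gives an at least 2.3-fold lower number from compound 1 to compound 4 (0.36 log units; beyond the scatter). Both steps start from a limit of the assay and not a number: the limit of > 100 ug/mL in this assay, at which 2 of the 4 values shown sit. The new group still falls short of 2,5-dimethoxyphenyl, with an 8.6-fold higher number from compound 2 to compound 4 (0.93 log units; beyond the scatter). The compounds shown leave open how a hydroxyl, an amine or a longer ether chain in place of methoxymethoxy would read here.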